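An Open-Chain Acyl Group in Place of Pyrazole

The compounds below may be only part of what the source reports. "The series", "measured", "known", "first", "only" and "open" are said of these compounds alone.

Of the compounds shown here, three have so far been measured in an assay on cells for positive allosteric modulation of Cystic fibrosis transmembrane conductance regulator variant F508del (Homo sapiens), with stated times of 10 min and 7 s, in the presence of a further agent that is not named here; a higher number here means that more compound is needed for the effect, a lower number that less compound is needed. Compound 1 `Cc1ccc(C(=O)Nc2sc3c(c2C(N)=O)CCOC3)s1` gives 778 nM, compound 2 `CC1Cc2c(sc(NC(=O)c3ccccc3O)c2C(N)=O)C(C)O1` gives 4 nM, and compound 3 `CC1(C)Cc2c(sc(NC(=O)c3ccn[nH]3)c2C(N)=O)C(C)(C)O1` gives 3 nM. Compound 3 thus stands at the lowest of the three numbers; compound 2 lies within the scatter of it, while compound 1 lies far beyond it. Compound 4 `CC(C)(C)CC(O)C(=O)Nc1sc2c(c1C(N)=O)CC(C)(C)OC2(C)C` differs from compound 3 in one place: a group of 7 heavy atoms (6 carbon, 1 oxygen; no ring) in place of a group of 5 heavy atoms (3 carbon, 2 nitrogen; one five-membered aromatic ring with 2 hetero atoms), on a carbonyl carbon. Within the data shown here, no measured pair shows a change of this kind, and every measured compound carries an aromatic ring on the carbonyl carbon, so the step cannot be read from the data. A moderate rise, beyond the scatter, is expected. The estimate for compound 4 is 30 nM, with a range from 6 nM to 150 nM, which corresponds to an expected step of a 10-fold higher number from compound 3 to compound 4 (1.00 log units; beyond the scatter).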

Compound 4, half-maximal effective concentration: 0.54 nM
Estimate against measurement, compound 4: 56-fold (1.74 log units) above; the measured number lies below the stated range.
By their numbers in this assay, from the lowest: compound 4; then compounds 3 and 2 (each within the scatter of the next); then compound 1.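

Putting the open-chain group in place of 1H-pyrazol-5-yl on the carbonyl carbon gives a 5.6-fold lower number from compound 3 to compound 4 (0.74 log units; beyond the scatter) and thus a lower number, not a higher one. Compound 4 therefore shows, on this shared core, that an aromatic ring at this place is not needed for a low number. No available evidence bears on why the step goes this way.

The compounds shown leave open whether the hydroxyl group of the chain contributes to the step. They also leave open how an amine in its place, or a longer chain, would compare.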